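Hydrazone aryl swap within the shared core series

This account rests on a few compounds, and the source may have more. Where it says the series, first, only, none or still open, it means among the compounds named here.

Among the measured compounds shown here, in a functional assay on MGC-803 cells (Homo sapiens) for antiproliferative activity, read by MTT assay, with a stated time of 72 h (a lower number here means a stronger inhibitor, a higher number a weaker inhibitor), compound 2 `CCCSc1nc(N/N=C/c2c[nH]c3ccccc23)c2nnn(Cc3ccccc3)c2n1` gives 7410 nM, the highest number of the three measured so far. Compound 3 `COc1cc(/C=N/Nc2nc(SCc3ccccc3)nc3c2nnn3Cc2ccccc2)cc(OC)c1OC` gives 1320 nM and compound 1 `C/C(=N\Nc1nc(SCc2ccccc2)nc2c1nnn2Cc1ccccc1)c1ccccc1O` gives 850 nM; both sit beyond the scatter below compound 2, but each differs from it in more than one place, so no single structural step can be read from them. Compound 4 `CCCSc1nc(N/N=C/c2ccc3ccccc3c2)c2nnn(Cc3ccccc3)c2n1` differs from compound 2 by naphthalen-2-yl in place of 1H-indol-3-yl on a carbon with a double bond to nitrogen. For the measured compounds named here, no measured pair isolates this change. The expectation is a modest move toward a lower number in this assay, of a size that may still fall within the scatter, expressed as the step of a 1.9-fold lower number from compound 2 to compound 4 (0.27 log units; within the scatter). Compound 4 is therefore estimated at 4000 nM, with a range from 1200 nM to 13000 nM.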

Compound 4, half-maximal inhibitory concentration: > 64000 nM
Compound 4 gave a limit, no number; the forecaster's own chance of this, stated with the estimate: 5%; middle value at least 16-fold (1.20 log units) away from the limit.
By their numbers in this assay, from the lowest: compounds 1 and 3 (each within the scatter of the next); then compound 2. At a limit, above all of these: compound 4.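

Naphthalen-2-yl in place of 1H-indol-3-yl on a carbon with a double bond to nitrogen gives an at least 8.6-fold higher number from compound 2 to compound 4 (0.93 log units; beyond the scatter) in this assay, the first single-place change that can be read in this series. Compound 4 reads only as a limit of the assay: the limit of > 64000 nM in this assay, at which 1 of the 4 values shown sits. This position is therefore sensitive to the identity of the aryl group.

The compounds shown leave open whether the step turns on the hydrogen-bond donor that leaves with 1H-indol-3-yl or on the rings themselves. A 1-methyl-1H-indol-3-yl group at this place would separate the two.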